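Ester in Place of Methyl on the Side Chain

A few compounds are considered here, and "the series" means these few. Any claim that something is new, unique, unknown or untested is made for them only; others in the source may bear on it.

Measured compounds:
Compound 1, `C=CCc1cc(C(C)=O)c(O)cc1OCCCCCC#N`: 81%
Compound 2, `C=CCc1cc(C(C)=O)c(O)cc1OCCCCCC`: 50%

Both compounds were tested in an assay on isolated protein for inhibition of leukotriene B4 receptor 1 (Homo sapiens), tested at 10 uM; on this read-out higher numbers stand for more inhibition at the one concentration tested (going by the name of the read-out) and lower numbers for less inhibition. Compound 2 stands lowest of the two numbers; its nearest neighbour is compound 1, and the step of a number 31 percentage points lower from compound 1 to compound 2 (beyond the scatter) lies beyond the scatter. Compound 3, `C=CCc1cc(C(C)=O)c(O)cc1OCCCCCC(=O)OC`, has not been measured. It differs from compound 2 in one place: methoxycarbonyl in place of methyl on a saturated chain carbon, five bonds along the chain from an oxygen on an aromatic ring. Within the data shown here, the only step that bears on this change is the one from compound 1 to compound 2, where a chain end carrying a nitrile, with its acceptor, gave the higher number and a plain methyl the lower. Compound 3 brings two hydrogen-bond acceptors back to that same chain end, so the expected step of a number 20 percentage points higher from compound 2 to compound 3 (beyond the scatter) is upward, probably beyond the scatter, though an ester is not a nitrile and the size is uncertain. Compound 3 is therefore expected to give 70%, within 45% to 90%.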

Compound 3, a percentage reported as inhibition, at one concentration (the size of the read-out at that concentration, not a potency): 106%
Compound 3: the middle estimate sits 36 percentage points below what was measured; measured number outside the range, above it.
By their numbers in this assay, from the lowest: compound 2; then compound 1; then compound 3.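

In this assay, methoxycarbonyl in place of methyl on this saturated chain carbon gives a number 56 percentage points higher from compound 2 to compound 3 (beyond the scatter), a large step that makes the chain end a strong lever on the number. Methoxycarbonyl in place of cyano gives a number 25 percentage points higher from compound 1 to compound 3 (beyond the scatter), so the two chain ends that carry hydrogen-bond acceptors also differ from each other, and the mere presence of an acceptor does not set the number. Among these three compounds, compound 3 stands highest, with both of its steps beyond the scatter.

From the compounds shown here alone, whether a carboxylic acid or an amide at this chain end would match the methyl ester remains open, as does whether the ester would hold its number on a shorter or longer chain. Nothing available explains why the three chain ends fall in this order.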